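A few compounds are considered here, and "the series" means these few. Any claim that something is new, unique, unknown or untested is made for them only; others in the source may bear on it.

Compound 1 `Cc1cc2c(cc1C(=O)N=C(N)N)S(=O)(=O)CC2C` is the point of reference in this series. In an assay on cells for inhibition of sodium/hydrogen exchanger (Oryctolagus cuniculus) (on this read-out higher numbers stand for weaker inhibition and lower numbers for stronger inhibition), compound 1 gives 44 nM. Compound 2 `COC1(C)CS(=O)(=O)c2cc(C(=O)N=C(N)N)c(C)cc21` carries one change relative to compound 1, namely (methoxy in place of hydrogen on a saturated ring carbon). In this assay compound 2 gives 40 nM, so that the step of a 1.1-fold lower number from compound 1 to compound 2 (0.04 log units; within the scatter) is a small one. Compound 3 `Cc1cc2c(cc1C(=O)N=C(N)N)S(=O)(=O)CC2` differs from compound 1 in its core: the difference is hydrogen in place of methyl on a saturated ring carbon. In this assay compound 3 gives 60 nM; the step of a 1.4-fold higher number from compound 1 to compound 3 (0.13 log units; within the scatter) again stays small, and compound 3 stands within the scatter of both compound 1 and compound 2, so no order among the three can be read from these numbers.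

Compound 4 `COC1CS(=O)(=O)c2cc(C(=O)N=C(N)N)c(C)cc21` is not yet measured. Relative to compound 3 its structure shows (methoxy in place of hydrogen on a saturated ring carbon). This is the same change as the one from compound 1 to compound 2, at a place described in the same words, methoxy in place of hydrogen on a saturated ring carbon, and it occurs twice among the compounds shown. For the measured compounds named here, the one instance already measured suggests that adding methoxy at this place leaves the number essentially unchanged.

For compound 3 to compound 4 a step of about a 1.1-fold lower number from compound 3 to compound 4 (0.04 log units; within the scatter) in this assay is therefore expected, because the earlier instance of the same change gave a 1.1-fold lower number from compound 1 to compound 2 (0.04 log units; within the scatter). Compound 4 is accordingly estimated at 55 nM. Compound 4 is expected to fall between 25 nM and 120 nM.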

Compound 4, half-maximal inhibitory concentration: 96 nM
Beside the measured number, compound 4's estimate is 1.7-fold (0.24 log units) below it; measured number inside the range.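

In this assay, the new instance of methoxy in place of hydrogen on a saturated ring carbon gives a 1.6-fold higher number from compound 3 to compound 4 (0.20 log units; within the scatter), and it does not differ from the earlier instance on the other core by more than two such steps can scatter: the same change on two cores in this assay, a 1.1-fold lower number (0.04 log units; within the scatter) from compound 1 to compound 2 and a 1.6-fold higher number (0.20 log units; within the scatter) from compound 3 to compound 4, 1.8-fold (0.25 log units) apart, within the scatter of two such steps. The same holds for hydrogen in place of methyl on a saturated ring carbon, where the new instance gives a 2.4-fold higher number from compound 2 to compound 4 (0.38 log units; beyond the scatter), a modest step beyond the scatter, while its earlier counterpart stays within it: the same change on two cores in this assay, a 1.4-fold higher number (0.13 log units; within the scatter) from compound 1 to compound 3 and a 2.4-fold higher number (0.38 log units; beyond the scatter) from compound 2 to compound 4, 1.8-fold (0.25 log units) apart, within the scatter of two such steps. Both changes can thus be carried between these two cores without a detectable difference, and only the combined exchange, methoxy in place of methyl, gives a modest step beyond the scatter, a 2.2-fold higher number from compound 1 to compound 4 (0.34 log units; beyond the scatter), but two pairs of small steps do not show that the steps are identical or that the agreement would hold on any further core.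

The compounds shown carry only hydrogen, methyl and methoxy on this saturated ring carbon, so it remains open whether a hydroxyl, an amine, a carboxylic acid or a longer chain such as ethoxy would keep the number in the same range. From the compounds shown here alone, it also remains open whether larger steps at this place would add up in the same way from one core to the other.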